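Adding a Chloro Group to an Aryl Amidine

A few compounds are considered here, and "the series" means these few. Any claim that something is new, unique, unknown or untested is made for them only; others in the source may bear on it.

Measured so far in an assay for inhibition of Nitric oxide synthase, inducible (Homo sapiens), with a stated time of 30 min, tested at 1 mM; on this read-out higher numbers stand for more inhibition at the one concentration tested (going by the name of the read-out) and lower numbers for less inhibition:
Compound 1, `N=C(NCCC(=O)c1ccccc1N)c1ccc(C(F)(F)F)cc1`: 68.6%
Compound 2, `COc1ccc(N)c(C(=O)CCNC(C)=N)c1`: 97.6%
Compound 3, `COc1ccc(N)c(C(=O)CCNC(=N)c2ccccc2)c1`: 94.7%

Compound 3 stands second highest of the three numbers. Its gap to compound 2 is within the scatter, so the two cannot be told apart, while compound 1 lies well below it, beyond the scatter. For the measured compounds named here, the only step between compounds that differ in one place is a number 2.9 percentage points lower from compound 2 to compound 3 (within the scatter), which is within the scatter, so the number stays level whether the carbon with a double bond to nitrogen carries a phenyl or a methyl.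

Compound 4, `COc1ccc(N)c(C(=O)CCNC(=N)c2ccc(Cl)cc2)c1`, differs from compound 3 in one place: chloro in place of hydrogen on an aromatic carbon. Going by the values given here, no measured step covers a chloro on this ring. Compound 1 carries a trifluoromethyl on its phenyl and gives a lower number, but it also lacks the methoxy of compound 3, so two changes separate them and the comparison carries little weight. The step of a number 4.7 percentage points lower from compound 3 to compound 4 (within the scatter) is therefore expected to stay within the scatter, with a slight downward lean allowed. Compound 4 is estimated at 90%, within 75% to 99%.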

Compound 4, a percentage reported as inhibition, at one concentration (the size of the read-out at that concentration, not a potency): 75.1%
Estimate against measurement, compound 4: 14.9 percentage points above, and the stated range covers the measured number.
By their numbers in this assay, from the lowest: compounds 1 and 4 (each within the scatter of the next); then compounds 3 and 2 (each within the scatter of the next).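

Placing a chloro on an aromatic carbon of the phenyl ring of compound 3, para to a large group, gives a number 19.6 percentage points lower from compound 3 to compound 4 (beyond the scatter) in this assay and shows that this ring position is not indifferent to substitution. Replacing the methyl of compound 2 with phenyl had left the number level, whereas replacing it with 4-chlorophenyl gives a number 22.5 percentage points lower from compound 2 to compound 4 (beyond the scatter) and so the fall appears only once the chloro is present. Nothing available here explains why the number falls.

As far as these compounds go, it remains open whether this fall is specific to chloro or would follow any group at this place, which a fluoro, a methyl or an amine there could show. From the compounds shown here alone, because each number comes from one concentration, the potencies of compound 3 and compound 4 also remain unknown.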